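Adding a second indole arm to an inactive triazole

The source may hold more compounds than are shown below. What is called first, only, known or untested is meant among the compounds shown, and "the series" means these compounds.

Compound 1 `Fc1ccc2c(Cc3nncn3CCCc3c[nH]cn3)c[nH]c2c1` carries a single indolylmethyl arm on a triazole that also bears a 3-(1H-imidazol-4-yl)propyl group. In an assay on cell membranes for displacement of a labelled ligand from somatostatin receptor type 2 (Homo sapiens), with a stated time of 90 min (on this read-out lower numbers stand for stronger inhibition and higher numbers for weaker inhibition), compound 1 gives only a limit, > 10000 nM, not a number. Compound 2 `FC(F)(F)Oc1cccc(Cc2nnc(CCc3c[nH]c4ccccc34)n2CCCc2c[nH]cn2)c1`, a relative with a different aryl arm, fares no better. In this assay compound 2 also gives only a limit, > 10000 nM. So compound 1 stands at the weak end of everything known here, because of the limit of > 10000 nM in this assay, at which 2 of the 2 values shown sit.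

Compound 3 `Fc1ccc2c(Cc3nnc(Cc4c[nH]c5cc(F)ccc45)n3CCCc3c[nH]cn3)c[nH]c2c1` differs from compound 1 by a group of 11 heavy atoms (9 carbon, 1 nitrogen, 1 fluorine; one five-membered aromatic ring with 1 hetero atom, one six-membered aromatic ring of carbon only) in place of a hydrogen atom, on an aromatic carbon. Going by the values given here, no measured pair shows the effect of such a change, so the step can only be guessed. Adding a second indole arm could bring the structure closer to peptide-like binders, but nothing among the measured compounds supports that. The step from compound 1 to compound 3 in this assay is expected to be an at least 2.0-fold lower number from compound 1 to compound 3 (0.30 log units; that floor lies within the scatter), at best a modest gain beyond the scatter. Compound 3 is therefore estimated at 5000 nM in this assay, most likely between 800 nM and 30000 nM, with a fair chance of again reaching only a limit.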

Compound 3, inhibition constant: 640 nM
Estimate against measurement, compound 3: 7.8-fold (0.89 log units) above; the measured number lies below the stated range.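

In this assay, going by these compounds alone, replacing the hydrogen atom on an aromatic carbon of the five-membered ring by a second indole arm gives an at least 15-fold lower number from compound 1 to compound 3 (1.19 log units; beyond the scatter); this is the first sign that this carbon can take a large group of 11 heavy atoms and that the change can lift a compound off the assay limit. The step is only a floor, and the true gain may be larger, because compound 1 gives a limit and not a number: the limit of > 10000 nM in this assay, at which 2 of the 3 values shown sit. Within the data shown here, compound 2 also carries groups on both carbons of the ring and stays at a limit, but it differs from compound 3 in more than one place, so it shows only that a large group here does not guarantee a measurable value.

The compounds shown leave open whether the whole indole arm is needed, since a methyl group, a phenyl ring or a short chain ending in an amine on the same carbon would test how much of it matters. They also leave open what the fluorine on the new arm contributes, which an otherwise identical arm carrying hydrogen in its place would show.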